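A few compounds are considered here, and "the series" means these few. Any claim that something is new, unique, unknown or untested is made for them only; others in the source may bear on it.

Measured compounds in the series:

Compound 1, `COc1ccc(C(O)(Cc2ccc(C)cc2)c2cccc3ccccc23)c(OC)c1OC`: > 20000 nM, a limit of the assay, not a number.
Compound 2, `COc1ccc(C(O)(Cc2ccc(F)cc2)c2cccc3ccccc23)c(OC)c1OC`: > 20000 nM, likewise only a limit.
Compound 3, `COc1ccc(/C(=C/c2ccc(F)cc2)c2cccc3ccccc23)c(OC)c1OC`: > 20000 nM, again only a limit.

All three were run in a functional assay on HCT-116 cells (Homo sapiens) for inhibition, read by sulforhodamine B assay, with a stated time of 48 h (a lower number here means a stronger inhibitor, a higher number a weaker inhibitor), and none returned a number; they share the same ceiling, (the limit of > 20000 nM in this assay, at which 3 of the 3 values shown sit). Going by the values given here, the one change that can be followed between measured compounds is methyl in place of fluoro on an aromatic carbon. Its size is not readable, a step that the two limits leave unreadable from compound 2 to compound 1, because both ends sit at the limit. Compound 3 carries a different core from compound 2; the difference between the two cores is not broken down here.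

Compound 4, `COc1ccc(/C(=C/c2ccc(C)cc2)c2cccc3ccccc23)c(OC)c1OC`, is the still unmeasured member. It differs from compound 3 by methyl in place of fluoro on an aromatic carbon. This is the same change as from compound 2 to compound 1, made at a place described in the same words, now on the core of compound 3. The earlier step gives no direction and no size, only two limits; the expectation for compound 4 can rest on nothing more than that. The step from compound 3 to compound 4 in this assay is therefore estimated to be flat, a step that the limit leaves unreadable from compound 3 to compound 4, with the most likely outcome another limit. Compound 4 is accordingly expected at 30000 nM, with a range estimated from 12000 nM to 90000 nM.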

Compound 4, half-maximal inhibitory concentration: > 20000 nM
Compound 4: no number, only a limit; the forecaster's own chance of this, stated with the estimate: 85%; the middle value lies beyond the limit too.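

In this assay no new step can be read between compound 3 and compound 4, because both sit at a limit of the assay and not at a number: the limit of > 20000 nM in this assay, at which 4 of the 4 values shown sit.

The compounds shown leave open how far beyond that limit each of them lies, and whether methyl in place of fluoro on an aromatic carbon changes the read-out at all on either core.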